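Cyclic amidine in place of isopropylamidine: cytotoxicity outlook

The source may hold more compounds than are shown below. What is called first, only, known or untested is meant among the compounds shown, and "the series" means these compounds.

The measured compounds are:
Compound 1, `c1ccc(OCCCOc2cccc(-c3cc4cc(C5=NCCN5)ccc4o3)c2)cc1`, 6500 nM
Compound 2, `N=C(N)c1ccc2oc(-c3cccc(OCCCCOc4ccccc4)c3)cc2c1`, 8100 nM
Compound 3, `CC(C)NC(=N)c1ccc2oc(-c3cccc(OCCCCOc4ccccc4)c3)cc2c1`, 36500 nM

In an ADME assay on L6 cells (Rattus norvegicus) for cytotoxicity, read by resazurin assay, with a stated time of 70 h (a higher number here means a weaker inhibitor, a lower number a stronger inhibitor), compound 3 gives the highest number of the three, compound 2 the nearest and compound 1 the furthest, both steps beyond the scatter. Among the compounds with values here, the one single-point step recorded is a 4.5-fold higher number from compound 2 to compound 3 (0.65 log units; beyond the scatter), so putting an isopropyl group on the amidine nitrogen of compound 2 moved the number upward by a modest but real amount.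

Compound 4, `c1ccc(OCCCCOc2cccc(-c3cc4cc(C5=NCCN5)ccc4o3)c2)cc1`, differs from compound 3 by a group of 5 heavy atoms (3 carbon, 2 nitrogen; one five-membered non-aromatic ring with 2 hetero atoms) in place of a group of 6 heavy atoms (4 carbon, 2 nitrogen; no ring), on an aromatic carbon. Within the data shown here, no measured step covers this exact change. Compound 1 carries the same five-membered group, though on a shorter linker, and compound 2 carries the open amidine without the isopropyl group; their values in this assay sit near each other and well under compound 3. The step from compound 2 to compound 3 suggests that removing the isopropyl group should reverse much of that rise, so compound 4 is expected to land close to compounds 1 and 2, with a downward step a 4.6-fold lower number from compound 3 to compound 4 (0.66 log units; beyond the scatter) estimated. Compound 4 is thus expected at about 8000 nM, within 3500 nM to 18000 nM.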

Compound 4, half-maximal inhibitory concentration: 9500 nM
Beside the measured number, compound 4's estimate is 1.2-fold (0.07 log units) below it, and the stated range covers the measured number.
By their numbers in this assay, from the lowest: compounds 1, 2 and 4 (each within the scatter of the next); then compound 3.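

In this assay the five-membered ring group gives a 3.8-fold lower number from compound 3 to compound 4 (0.58 log units; beyond the scatter) on the same aromatic carbon, showing directly that the higher number of compound 3 does not carry over to this ring group. Against the open amidine without isopropyl, the ring group gives a 1.2-fold higher number from compound 2 to compound 4 (0.07 log units; within the scatter) at this position, and phenoxymethyl in place of phenoxy on the chain gives a 1.5-fold higher number from compound 1 to compound 4 (0.16 log units; within the scatter) with the ring group kept, so neither change separates these compounds. Nothing measured here accounts for any of these steps.

The compounds shown leave open whether a six-membered ring in place of the five-membered one would stay level with compound 4. They also leave open whether a methyl or a cyclohexyl on the amidine nitrogen would raise the number as isopropyl does.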